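Tetrazole for Triazole Across Two Thiazole Hydrazides

A few compounds are considered here, and "the series" means these few. Any claim that something is new, unique, unknown or untested is made for them only; others in the source may bear on it.

Compound 2 `Cc1ccc(-c2cs/c(=N/NC(=O)CSc3nncn3C)n2-c2ccccc2)cc1` and compound 3 `Cn1cnnc1SCC(=O)N/N=c1/scc(-c2ccccc2)n1-c1ccccc1` share one core; compound 3 arises from compound 2 through (hydrogen in place of methyl on an aromatic carbon). In a functional assay on C6 cells (Rattus norvegicus) for cytotoxicity, read by MTT assay, with a stated time of 24 h (a higher number here means a weaker inhibitor, a lower number a stronger inhibitor), compound 2 gives 56 ug/mL, and in this assay compound 3 gives 68.3 ug/mL, a difference of a 1.2-fold higher number from compound 2 to compound 3 (0.09 log units; within the scatter). Compound 1 `Cc1ccc(-c2cs/c(=N/NC(=O)CSc3nnnn3-c3ccccc3)n2-c2ccccc2)cc1` arises from compound 2 through (1-phenyl-1H-tetrazol-5-yl in place of 4-methyl-4H-1,2,4-triazol-3-yl on a sulfur), and in this assay compound 1 gives 14.7 ug/mL, which is a 3.8-fold lower number from compound 2 to compound 1 (0.58 log units; beyond the scatter). Compound 4 `O=C(CSc1nnnn1-c1ccccc1)N/N=c1/scc(-c2ccccc2)n1-c1ccccc1` has not yet been measured; it arises from compound 3 through the same change, (1-phenyl-1H-tetrazol-5-yl in place of 4-methyl-4H-1,2,4-triazol-3-yl on a sulfur), at a place described in the same words. Resting on the single earlier instance of this change, a 3.8-fold lower number from compound 2 to compound 1 (0.58 log units; beyond the scatter), the step from compound 3 to compound 4 in this assay is expected to be a 3.8-fold lower number from compound 3 to compound 4 (0.58 log units; beyond the scatter). Compound 4 is therefore estimated at 18 ug/mL, most likely between 9 ug/mL and 36 ug/mL.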

Compound 4, half-maximal inhibitory concentration: 8.3 ug/mL
Compound 4: middle estimate off by 2.2-fold (0.34 log units), on the high side, and the stated range ends above it.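

In this assay, putting 1-phenyl-1H-tetrazol-5-yl in place of 4-methyl-4H-1,2,4-triazol-3-yl on the sulfur again gives a lower number, an 8.2-fold lower number from compound 3 to compound 4 (0.92 log units; beyond the scatter), and the two instances of this change agree: the same change on two cores in this assay, a 3.8-fold lower number (0.58 log units; beyond the scatter) from compound 2 to compound 1 and an 8.2-fold lower number (0.92 log units; beyond the scatter) from compound 3 to compound 4, 2.2-fold (0.33 log units) apart, within the scatter of two such steps Hydrogen in place of methyl on an aromatic carbon gives a 1.8-fold lower number from compound 1 to compound 4 (0.25 log units; within the scatter), which also agrees with its earlier instance: the same change on two cores in this assay, a 1.2-fold higher number (0.09 log units; within the scatter) from compound 2 to compound 3 and a 1.8-fold lower number (0.25 log units; within the scatter) from compound 1 to compound 4, 2.2-fold (0.33 log units) apart, within the scatter of two such steps The tetrazole change therefore carried over between two cores that differ only by that methyl, but two pairs do not show that it would hold on a core that differs more.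

The tetrazole ring and its phenyl ring enter together, so which of them accounts for the step remains open. A 1-methyl-1H-tetrazol-5-yl group on the same sulfur would separate the two.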